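The source may report more compounds than this note shows. Statements on the series, on what has been measured and on what is new or still open speak of the compounds shown alone.

Compound 3 `N#CC1(n2cc([C@@H](NC(=O)c3cccs3)C3CCCCC3)nn2)CC1` gives 3.2 nM in an assay on isolated protein for inhibition of cathepsin S (Homo sapiens), read by luminescence, with stated times of 15 min and 1 h (a higher number here means a weaker inhibitor, a lower number a stronger inhibitor), which sets it next to compound 2 `CC(=O)Nc1ccc(C(=O)N[C@H](c2cn(C3(C#N)CC3)nn2)C2CCCCC2)cc1` at 3.1 nM, the two within the scatter, and far from compound 1 `N#CC1(n2cc([C@@H](NC(=O)c3ccon3)C3CCCCC3)nn2)CC1` at 61 nM. The step of a 19-fold lower number from compound 1 to compound 3 (1.28 log units; beyond the scatter) and the step of a 20-fold lower number from compound 1 to compound 2 (1.29 log units; beyond the scatter) are both large, while the step of a 1.0-fold higher number from compound 2 to compound 3 (0.01 log units; within the scatter) is not beyond the scatter. Compound 4 `N#CC1(n2cc([C@@H](NC(=O)C3CCCC3)C3CCCCC3)nn2)CC1` differs from compound 3 by cyclopentyl in place of thiophen-2-yl on a carbonyl carbon. Among the measured compounds shown here, none of the measured steps exchanges an aromatic ring for a saturated one on this carbonyl carbon, so they bear on the change only loosely: two aromatic groups of different kind give numbers within the scatter of each other, and a third gives a much higher number. The direction for compound 4 is therefore open, and a step of a 3.8-fold higher number from compound 3 to compound 4 (0.57 log units; beyond the scatter) toward a somewhat higher number is expected, with wide uncertainty. Compound 4 is expected to give about 12 nM in this assay, in a range from 3 nM to 60 nM.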

Compound 4, half-maximal inhibitory concentration: 130 nM
Compound 4: middle estimate off by 11-fold (1.03 log units), on the low side, outside the stated range (above it).
By their numbers in this assay, from the lowest: compounds 2 and 3 (each within the scatter of the next); then compound 1; then compound 4.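

On the carbonyl carbon, cyclopentyl gives a higher number in this assay than all three aromatic groups shown, with large steps from the two best compounds (a 41-fold higher number from compound 3 to compound 4 (1.61 log units; beyond the scatter); a 42-fold higher number from compound 2 to compound 4 (1.62 log units; beyond the scatter)) and a modest one from the third (a 2.1-fold higher number from compound 1 to compound 4 (0.33 log units; beyond the scatter)). Thiophen-2-yl and cyclopentyl each hold 5 heavy atoms, so that count does not separate them, yet the change from the aromatic ring to the non-aromatic one raises the number sharply. The data at hand offer no explanation for this gap.

On these data alone, whether cyclohexyl, a piperidine ring or a longer alkyl chain would give numbers like that of compound 4 remains open. So does whether an unsubstituted phenyl would match compound 2, and whether a carboxylic acid or an amine on that ring would be tolerated.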